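The compounds below may be only part of what the source reports. "The series", "measured", "known", "first", "only" and "open" are said of these compounds alone.

Values in an ADME assay on SH-SY5Y cells (Homo sapiens) for cytotoxicity, read by sulforhodamine B assay, with a stated time of 72 h; on this read-out lower numbers stand for stronger inhibition and higher numbers for weaker inhibition:
- Compound 1 `O=C(NCc1ccccn1)C1CCN(Cc2ccccc2)CC1`: > 100000 nM (a limit)
- Compound 2 `O=C(NCc1ccncc1)C1CCN(Cc2ccccc2)CC1`: 3370 nM
- Compound 3 `O=C(NC1CCCc2ccccc21)C1CCN(Cc2ccccc2)CC1`: 99300 nM

Compound 1 gives only a limit, (the limit of > 100000 nM in this assay, at which 1 of the 3 values shown sits). That leaves two true numbers, and compound 2 holds the lower one, 3370 nM, with compound 3 at 99300 nM.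

Compound 4 `O=C(NCCN1CCCCC1)C1CCN(Cc2ccccc2)CC1` is unmeasured. It carries (piperidin-1-yl)methyl in place of the pyridin-4-yl of compound 2, on a saturated chain carbon bound to an amide-type nitrogen: (piperidin-1-yl)methyl in place of pyridin-4-yl on a saturated chain carbon bound to an amide-type nitrogen.

Among the measured compounds shown here, the one measured step at this place is an at least 29-fold lower number from compound 1 to compound 2 (1.47 log units; beyond the scatter). It is large, so the read-out can respond strongly to a change here. However, that step only exchanges pyridin-2-yl for pyridin-4-yl, so it gives no direct size for losing the pyridine ring altogether.

With pyridin-4-yl gone, a partial move from compound 2 toward compound 3 at 99300 nM is expected. A moderate rise is expected, with an estimated 4.5-fold higher number from compound 2 to compound 4 (0.65 log units; beyond the scatter). For compound 4 the estimated value is 15000 nM, with an expected range of 3000 nM to 70000 nM.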

Compound 4, half-maximal inhibitory concentration: > 100000 nM
Compound 4: a limit, no number; the forecaster's own chance of this, stated with the estimate: 15%; at least 6.6-fold (0.82 log units) between middle value and limit.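

In this assay, (piperidin-1-yl)methyl in place of pyridin-4-yl on a saturated chain carbon bound to an amide-type nitrogen gives an at least 29-fold higher number from compound 2 to compound 4 (1.47 log units; beyond the scatter), so this place responds strongly to more than a swap of pyridine isomers. Among compound 1, compound 2 and compound 4, which differ only here, compound 2 alone gives a true number, so within this small set a measurable value goes with pyridin-4-yl. Compound 4 gives only a limit, as does compound 1, and the step between them cannot be read: the limit of > 100000 nM in this assay, at which 2 of the 4 values shown sit.

The change from (pyridin-4-yl)methyl to 2-(piperidin-1-yl)ethyl alters ring and chain length together, and the compounds shown do not separate the two. A 2-(pyridin-4-yl)ethyl group and a (piperidin-4-yl)methyl group would pull these apart, while pyridin-3-yl would complete the pyridine comparison.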